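The compounds below may be only part of what the source reports. "The series", "measured", "known", "first", "only" and "open" are said of these compounds alone.

The two measured compounds share one core and differ only at an amide-type nitrogen. In an ADME assay on Caco-2 cells (Homo sapiens) for permeability, in the apical to basolateral direction (a lower number here means that the compound crosses the layer more slowly, a higher number that the compound crosses the layer faster), compound 1 `NC(=O)c1cccc(Oc2ccc3c(c2)c(=O)ncn3Cc2c(F)cc(F)cc2F)c1C(F)(F)F` gives 1.9 10^-6 cm/s. Compound 2 `O=C(Nc1cccnc1)c1cccc(Oc2ccc3c(c2)c(=O)ncn3Cc2c(F)cc(F)cc2F)c1C(F)(F)F`, which carries a pyridin-3-yl group on that nitrogen, gives 0.26 10^-6 cm/s in this assay. That single change is the step of a 7.3-fold lower number from compound 1 to compound 2 (0.86 log units; beyond the scatter), so compound 2 holds the lowest of the two numbers, with compound 1 standing a clear step above it.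

Compound 3 `O=c1ncn(Cc2c(F)cc(F)cc2F)c2ccc(Oc3cccc(-c4ccc5[nH]cnc5c4)c3C(F)(F)F)cc12` keeps the core of compound 2 but swaps the side group: 1H-benzimidazol-5-yl in place of (pyridin-3-yl)carbamoyl on an aromatic carbon. Among the compounds with values here, only one measured step exists, a 7.3-fold lower number from compound 1 to compound 2 (0.86 log units; beyond the scatter), and it bears on this change just in part: it shows what the pyridin-3-yl group on the amide nitrogen did, while compound 3 drops the whole (pyridin-3-yl)carbamoyl group, amide included, and brings in a ring system with no measured counterpart here. The change therefore points back toward the region of compound 1 rather than beyond it, but with real uncertainty. The expected step is a 5.8-fold higher number from compound 2 to compound 3 (0.76 log units; beyond the scatter). For compound 3 the estimated value in this assay is 1.5 10^-6 cm/s, with a likely range from 0.4 10^-6 cm/s to 5 10^-6 cm/s.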

Compound 3, apparent permeability: 0.4 10^-6 cm/s
Estimate against measurement, compound 3: 3.8-fold (0.57 log units) above; low and high end bracket the measured number.
By their numbers in this assay, from the lowest: compounds 2 and 3 (each within the scatter of the next); then compound 1.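

In this assay, exchanging the (pyridin-3-yl)carbamoyl group for 1H-benzimidazol-5-yl on this aromatic carbon, ortho to a trifluoromethyl group, is a 1.5-fold higher number from compound 2 to compound 3 (0.19 log units; within the scatter), so these two quite different groups cannot be told apart here, even though one keeps an amide link and the other has none. Set against the plain carbamoyl group, the same fused ring system is a 4.8-fold lower number from compound 1 to compound 3 (0.68 log units; beyond the scatter), which places compound 1 clearly above both compound 2 and compound 3, so among these three compounds a low number does not depend on the amide link being present. No accompanying measurement explains why the two groups read alike.

The compounds shown leave open whether any ring system at this carbon would give a similar number or only these two, and a simple phenyl ring or a small group such as an amine or a carboxylic acid could help separate those possibilities. They also leave open how a longer chain at this carbon would compare, and whether the same reading would hold on any other core.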